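Isopropyl for Fluoro on the Fused Ring of Compound 3

The source may report more compounds than this note shows. Statements on the series, on what has been measured and on what is new or still open speak of the compounds shown alone.

Compound 3 `CCC(/C=C1\OC(=O)NC1=O)(CC)c1ccc(-c2ccc3cccc(F)c3c2)[nH]c1=O` stands lowest of the three compounds measured in an assay on membranes from Chem-1 cells for displacement of a labelled ligand from prostaglandin E2 receptor EP3 subtype (Homo sapiens), read by scintillation counting, with a stated time of 2 h (on this read-out lower numbers stand for stronger inhibition and higher numbers for weaker inhibition), where compound 3 gives 13 nM. Compound 1 `CCC(/C=C1\OC(=O)NC1=O)(CC)c1ccc(-c2ccc3cc(F)cc(F)c3c2)[nH]c1=O` gives 28 nM in this assay, and compound 2 `CC(C)C(c1ccc(-c2ccc3cccc(F)c3c2)[nH]c1=O)C1C(=O)NC(=O)N1C` gives 46 nM. Going by the values given here, the one step between compounds that differ in a single place, a 2.2-fold lower number from compound 1 to compound 3 (0.33 log units; beyond the scatter), concerns a fluoro group on the fused system of two rings. Compound 4 `CCC(/C=C1\OC(=O)NC1=O)(CC)c1ccc(-c2ccc3cccc(C(C)C)c3c2)[nH]c1=O` differs from compound 3 in one place: isopropyl in place of fluoro on an aromatic carbon. Among the compounds with values here, the step from compound 1 to compound 3 shows that a change at this fused ring system can move the number beyond the scatter, but none of the measured compounds carries an isopropyl anywhere, so the direction of the present change is not settled by the data. A move toward a higher number is judged somewhat more likely than a lower one, and compound 4 is expected to show a 2.3-fold higher number from compound 3 to compound 4 (0.36 log units; beyond the scatter) in this assay. Compound 4 is estimated at 30 nM, with a range from 8 nM to 120 nM.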

Compound 4, inhibition constant: 120 nM
For compound 4 the middle estimate is 4.0-fold (0.60 log units) below the measured one, within the range that was stated.
By their numbers in this assay, from the lowest: compound 3; then compounds 1 and 2 (each within the scatter of the next); then compound 4.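

At this place on the fused system of two rings, isopropyl in place of fluoro is not tolerated without loss in this assay: the step is a 9.2-fold higher number from compound 3 to compound 4 (0.97 log units; beyond the scatter), a move to weaker inhibition. The earlier step, a 2.2-fold lower number from compound 1 to compound 3 (0.33 log units; beyond the scatter), involved only fluoro and hydrogen, whereas this change shows that a branched carbon group with 3 heavy atoms can shift the number well beyond the scatter. The data shown offer no measurement that explains this shift.

The compounds shown leave open how a methyl, an ethyl, a chloro or a methoxy group would read at this place, so it cannot be said where between fluoro and isopropyl the loss sets in. They also leave open whether isopropyl would give a similar step on the core of compound 2.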